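Methylamino in place of methyl on a sulfonyl sulfur

The source may hold more compounds than are shown below. What is called first, only, known or untested is meant among the compounds shown, and "the series" means these compounds.

Three compounds were measured in an assay on isolated protein for inhibition of phosphatidylinositol 4,5-bisphosphate 3-kinase catalytic subunit beta isoform (Homo sapiens); a higher number here means a weaker inhibitor, a lower number a stronger inhibitor:

Compound 1 `CCN(CC)S(=O)(=O)c1cncc(-c2ccn3nc(N)nc3c2)c1`: 25100000 nM
Compound 2 `CC1(C)CCN1S(=O)(=O)c1cncc(-c2ccn3nc(N)nc3c2)c1`: 50100000 nM
Compound 3 `CS(=O)(=O)c1cncc(-c2ccn3nc(N)nc3c2)c1`: 39800000 nM

Compound 3 stands second highest of the three numbers. Its nearest neighbour is compound 2, a 1.3-fold lower number from compound 2 to compound 3 (0.10 log units; within the scatter); its furthest is compound 1, a 1.6-fold higher number from compound 1 to compound 3 (0.20 log units; within the scatter). All three compounds share one core and differ only in the group attached to the sulfonyl sulfur.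

Compound 4 `CNS(=O)(=O)c1cncc(-c2ccn3nc(N)nc3c2)c1` differs from compound 3 by methylamino in place of methyl on a sulfonyl sulfur. Going by the values given here, the steps that bear on this change are the ones that also exchange the group on the sulfonyl sulfur: a 2.0-fold higher number from compound 1 to compound 2 (0.30 log units; within the scatter), a 1.6-fold higher number from compound 1 to compound 3 (0.20 log units; within the scatter) and a 1.3-fold lower number from compound 2 to compound 3 (0.10 log units; within the scatter). None of them reached beyond the scatter, and the change to compound 4 is of the same kind, an exchange at the same place. The expected step in this assay is therefore none beyond the scatter, a 1.0-fold higher number from compound 3 to compound 4 (0.00 log units; within the scatter). Compound 4 is estimated at 40000000 nM, with a range from 13000000 nM to 120000000 nM.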

Compound 4, half-maximal inhibitory concentration: 39800000 nM
For compound 4 the middle estimate is 1.0-fold (0.00 log units) above the measured one, within the range that was stated.
By their numbers in this assay, from the lowest: compounds 1, 3, 4 and 2 (each within the scatter of the next).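

In this assay, the exchange of methyl for methylamino on the sulfonyl sulfur gives no change at the digits printed from compound 3 to compound 4 (within the scatter), so adding the hydrogen-bond donor that methylamino brings is not accompanied by any step beyond the scatter. The two other new comparisons also stay within the scatter, at a 1.3-fold lower number from compound 2 to compound 4 (0.10 log units; within the scatter) and a 1.6-fold higher number from compound 1 to compound 4 (0.20 log units; within the scatter), so methyl, methylamino, diethylamino and 2,2-dimethylazetidin-1-yl at this place are not told apart by these numbers. Nothing available here accounts for this result.

From the compounds shown here alone, it remains open whether a different group on the sulfonyl sulfur, such as a carboxylic acid, a primary amine or a longer chain ending in an amine, would move the number beyond the scatter. Going by these compounds alone, it is also open whether methylamino in place of methyl would give the same result on a core other than the one these four compounds share.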